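Ester chain extension on two related cores

The compounds below may be only part of what the source reports. "The series", "measured", "known", "first", "only" and "open" are said of these compounds alone.

Values in an assay on membranes from CHO cells for displacement of a labelled ligand from adenosine receptor A1 (Homo sapiens), read by scintillation counting, with a stated time of 60 min, tested at 1 uM; on this read-out higher numbers stand for more inhibition at the one concentration tested (going by the name of the read-out) and lower numbers for less inhibition:
compound 1, `COC(=O)C1=C(C)NC(=O)NC1c1cccs1`: 6%
compound 2, `CCCOC(=O)C1=C(C)NC(=O)NC1c1cccs1`: 43%
compound 3, `COC(=O)C1=C(C)NC(=S)NC1c1cccs1`: 1%

Compound 1 and compound 2 share a core and differ only by ethyl in place of hydrogen on a saturated chain carbon bound to an oxygen next to a carbonyl group. For the measured compounds named here, this change gives a number 37 percentage points higher from compound 1 to compound 2 (beyond the scatter), the one large step. Compound 3 stands on a different core; the difference between the two cores is not broken down here. In this assay compound 3 gives 1%, which lies within the scatter of compound 1, so the two cores look alike at the methyl ester stage.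

Compound 4, `CCCOC(=O)C1=C(C)NC(=S)NC1c1cccs1`, is not yet measured. It differs from compound 3 by ethyl in place of hydrogen on a saturated chain carbon bound to an oxygen next to a carbonyl group, the same change that carries compound 1 to compound 2, at the same place. An increase is expected from compound 3 to compound 4 of about a number 34 percentage points higher from compound 3 to compound 4 (beyond the scatter), resting on a number 37 percentage points higher from compound 1 to compound 2 (beyond the scatter) and on compound 3 starting near compound 1. Compound 4 is therefore estimated at 35%, with the expected range running from 10% to 60%.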

Compound 4, a percentage reported as inhibition, at one concentration (the size of the read-out at that concentration, not a potency): 7%
Compound 4: the middle estimate sits 28 percentage points above what was measured; measured number below the stated range.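

In this assay, ethyl in place of hydrogen on a saturated chain carbon bound to an oxygen next to a carbonyl group gives a number 6 percentage points higher from compound 3 to compound 4 (within the scatter), so the methoxycarbonyl to propoxycarbonyl change yields no readable gain on the core of compound 3. The step does not carry over from one core to the other in this series: the same change on two cores in this assay, a number 37 percentage points higher (beyond the scatter) from compound 1 to compound 2 and a number 6 percentage points higher (within the scatter) from compound 3 to compound 4, 31 percentage points apart, beyond the scatter of two such steps. This shows that the size of the step differs between these two cores, but it does not show which part of the difference between the cores accounts for that, and one pair of steps at one concentration gives no rule for other cores or other ester chains.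

Still open, going by these compounds, is whether an ethyl ester, a butyl ester or a benzyl ester would behave differently on the two cores, or whether the core of compound 3 responds to any ester chain at all. Single-concentration values also leave open how these compounds compare as full potencies.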